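Cyclopropyl Amide Replaces Aryl Amide in Clearance Series

This account rests on a few compounds, and the source may have more. Where it says the series, first, only, none or still open, it means among the compounds named here.

Of the compounds shown here, three sharing one core have been measured in an in vitro ADME assay on microsomes from liver (Mus musculus) for pharmacokinetics, read by LC-MS, with a stated time of 10 min, tested at 1 uM; a higher number here means faster removal of the compound, a lower number slower removal. Compound 1 `CN1C[C@H](C(=O)Nc2ccccc2)[C@@H](c2ccc(/C=C/C(=O)Nc3ccccc3N)cc2)C1` gives 67 mL/min/kg. Compound 2 `CN1C[C@H](C(=O)Nc2ccc(C#N)cc2)[C@@H](c2ccc(/C=C/C(=O)Nc3ccccc3N)cc2)C1` gives 35 mL/min/kg in this assay, a change of a 1.9-fold lower number from compound 1 to compound 2 (0.28 log units; within the scatter). Compound 3 `CN1C[C@H](C(=O)Nc2ccc(F)c(Br)c2)[C@@H](c2ccc(/C=C/C(=O)Nc3ccccc3N)cc2)C1` gives 43 mL/min/kg in this assay, and its steps from the other two, a 1.6-fold lower number from compound 1 to compound 3 (0.19 log units; within the scatter) and a 1.2-fold higher number from compound 2 to compound 3 (0.09 log units; within the scatter), both stay within the scatter, so compound 3 cannot be told apart from compound 1 or compound 2 on these numbers.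

Compound 4 `CN1C[C@H](C(=O)NC2CC2)[C@@H](c2ccc(/C=C/C(=O)Nc3ccccc3N)cc2)C1` has not been measured. It differs from compound 3 by cyclopropyl in place of 3-bromo-4-fluorophenyl on an amide-type nitrogen. Among the measured compounds shown here, the steps that bear on this change are those that alter the same amide-type nitrogen substituent, from compound 1 to compound 3 and from compound 2 to compound 3, and neither reached beyond the scatter. The expected step in this assay is therefore a 1.0-fold higher number from compound 3 to compound 4 (0.02 log units; within the scatter), with no direction favoured. The estimate for compound 4 in this assay is 45 mL/min/kg, expected to fall between 22 mL/min/kg and 90 mL/min/kg.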

Compound 4, clearance: 7 mL/min/kg
Estimate against measurement, compound 4: 6.4-fold (0.81 log units) above; the measured number lies below the stated range.
By their numbers in this assay, from the lowest: compound 4; then compounds 2, 3 and 1 (each within the scatter of the next).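

In this assay the substituent on this amide-type nitrogen had moved the number only within the scatter while it stayed aromatic, but cyclopropyl gives a step beyond the scatter against the 3-bromo-4-fluorophenyl partner (a 6.1-fold lower number from compound 3 to compound 4 (0.79 log units; beyond the scatter)), the 4-cyanophenyl partner (a 5.0-fold lower number from compound 2 to compound 4 (0.70 log units; beyond the scatter)) and the phenyl partner (a 9.6-fold lower number from compound 1 to compound 4 (0.98 log units; beyond the scatter)). The position therefore does respond, and among these four compounds the lower number goes with the three-membered non-aromatic ring, with no aryl compound going against this. Nothing shown accounts for the difference.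

Among the compounds shown here, only one non-aromatic group stands on this nitrogen, so it remains open whether the lower number belongs to cyclopropyl itself or would also come with cyclobutyl, cyclohexyl or an isopropyl group. As far as these compounds go, it also remains open whether a benzyl group here would side with the aryl compounds or with compound 4.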